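The compounds below may be only part of what the source reports. "The series", "measured", "known", "first", "only" and "open" are said of these compounds alone.

Measured so far:
compound 1 `CC(=O)Nc1ccc(OC(=S)Nc2ccc(Sc3ccc(C(F)(F)F)cc3)cc2)cc1` — 9.02
compound 2 `Oc1ccc(OC(=S)Nc2ccc(Oc3ccc(C(F)(F)F)cc3)cc2)cc1` — 9.23

Of the compounds shown here, two have been measured in a physicochemical assay for acid dissociation. Compound 1 gives 9.02, and compound 2 gives 9.23. Of the two numbers, compound 2 shows the higher one, but the gap to compound 1 lies within the scatter of this measurement, so the two cannot be told apart. Compound 3 `O=[N+]([O-])c1ccc(Oc2ccc(NC(=S)Oc3ccc(O)cc3)cc2)cc1` is the next to be measured in this assay. It differs from compound 2 in one place: nitro in place of trifluoromethyl on an aromatic carbon; the nitro group sits on an aromatic carbon of a six-membered aromatic ring of carbon only, para to a large group. Going by the values given here, no measured pair shows a step of this kind, so there is nothing to lean on beyond the two numbers. The change lies away from the part of the molecule most likely to give up a proton, and the expected step from compound 2 to compound 3 in this assay is a number 0.13 log units lower from compound 2 to compound 3 (within the scatter), small and, if anything, downward, hardly beyond the scatter. Compound 3 is therefore expected to give about 9.1, within a range from 8.7 to 9.5.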

Compound 3, acid dissociation constant: 9.23
The estimate for compound 3 lay 0.13 log units below the measured number, and the stated range covers the measured number.
By their numbers in this assay, from the lowest: compounds 1, 2 and 3 (each within the scatter of the next).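

In this assay, nitro in place of trifluoromethyl on an aromatic carbon, para to a large group, gives no change at the digits printed from compound 2 to compound 3 (within the scatter). This is the only step shown between compounds that differ in one place, and it gives the first direct reading for this position: exchanging these two groups there leaves the number unmoved, even though the two groups differ in their atoms and in their hydrogen-bond acceptor counts. No measurement shown here accounts for this result.

The compounds shown leave open whether an amine or a carboxylic acid on the same aromatic carbon would also leave the number in place. They also leave open whether this one pair holds for the same exchange on a different core.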